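Indole, benzimidazole and pyrimidine variants on the chloroaryl carbon

The source may hold more compounds than are shown below. What is called first, only, known or untested is meant among the compounds shown, and "the series" means these compounds.

Measured compounds in an assay on C3H 10T1/2 cells for inhibition of Sonic hedgehog protein (Mus musculus), read by a luciferase reporter; a lower number here means a stronger inhibitor, a higher number a weaker inhibitor:
compound 1, `Cc1nc(C(F)(F)F)ccc1C(=O)Nc1ccc(Cl)c(-c2cc3ccccc3[nH]2)c1`: 500 nM
compound 2, `Cc1nc(C(F)(F)F)ccc1C(=O)Nc1ccc(Cl)c(-c2nc3ccccc3n2C)c1`: 9 nM
compound 3, `Cc1nc(C(F)(F)F)ccc1C(=O)Nc1ccc(Cl)c(C(=O)Nc2ccccc2)c1`: 140 nM

Compound 2 gives the lowest number of the three in this assay, and both steps that connect it to the others lie beyond the scatter: a 56-fold lower number from compound 1 to compound 2 (1.74 log units; beyond the scatter) and a 16-fold higher number from compound 2 to compound 3 (1.19 log units; beyond the scatter). The third step, a 3.6-fold lower number from compound 1 to compound 3 (0.55 log units; beyond the scatter), is modest by comparison. Compound 2 is therefore the strongest inhibitor measured so far.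

Compound 4, `Cc1nc(C(F)(F)F)ccc1C(=O)Nc1ccc(Cl)c(-c2ncccn2)c1`, differs from compound 2 in one place: pyrimidin-2-yl in place of 1-methyl-1H-benzimidazol-2-yl on an aromatic carbon. The two steps that bear on this change are the two that exchange the 1-methyl-1H-benzimidazol-2-yl group for something else, and both were large in the direction of a higher number. Neither involves pyrimidin-2-yl, so they set only a direction and a rough scale. The entering group keeps the count of hydrogen-bond donors and acceptors of the group that leaves but is smaller and lacks the fused six-membered aromatic ring of carbon only. The expectation is a step beyond the scatter toward a higher number, of roughly a 5.6-fold higher number from compound 2 to compound 4 (0.74 log units; beyond the scatter), smaller than the two measured exchanges. Compound 4 is estimated at 50 nM in this assay, with a range of 15 nM to 200 nM.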

Compound 4, half-maximal inhibitory concentration: 8000 nM
Compound 4: the middle estimate sits 160-fold (2.20 log units) below what was measured; measured number above the stated range.
By their numbers in this assay, from the lowest: compound 2; then compound 3; then compound 1; then compound 4.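

At this aromatic carbon, ortho to a chloro group, two groups with the same counts of hydrogen-bond donors and acceptors are separated in this assay by an 890-fold higher number from compound 2 to compound 4 (2.95 log units; beyond the scatter), so those counts alone do not fix the number at this position. Pyrimidin-2-yl also falls behind the two weaker groups, with a 57-fold higher number from compound 3 to compound 4 (1.76 log units; beyond the scatter) and a 16-fold higher number from compound 1 to compound 4 (1.20 log units; beyond the scatter), which makes compound 4 the weakest of the four and shows that a ring carrying two nitrogens does not by itself preserve activity here, while compound 1, with its fused six-membered ring of carbon only, shows that such a ring is not sufficient either. Nothing available explains the size of the change from 1-methyl-1H-benzimidazol-2-yl to pyrimidin-2-yl.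

Compound 1 and compound 2 differ in both a ring nitrogen and a methyl group, and 1H-benzimidazol-2-yl or 1-methyl-1H-indol-2-yl at this carbon would separate those two features. Going by these compounds, it also remains open whether pyridin-2-yl, or a pyrimidin-2-yl ring carrying a methyl group or an amine, would give a number closer to that of the 1-methyl-1H-benzimidazol-2-yl group.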